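Fluoro for methoxy on the aryl ether of compound 1

This account rests on a few compounds, and the source may have more. Where it says the series, first, only, none or still open, it means among the compounds named here.

Measured compounds:
compound 1, `COc1ccc(OCc2cc(C)nc(-c3ccccn3)n2)cc1` — 7940 nM
compound 2, `Cc1cc(COc2ccccc2S(C)(=O)=O)nc(-c2ccccn2)n1` — > 39800 nM
compound 3, `Cc1cc(COc2cccc(S(C)(=O)=O)c2)nc(-c2ccccn2)n1` — > 39800 nM

Among the compounds with values here, in a functional assay on cells for antagonist activity at Free fatty acid receptor 1 (Homo sapiens), read by TR-FRET and inositol phosphate accumulation, with a stated time of 2 h (on this read-out higher numbers stand for weaker inhibition and lower numbers for stronger inhibition), compound 1 gives 7940 nM, and this is the only true number among the three measured compounds. For compound 2 the result is a limit of the assay, > 39800 nM. For compound 3 the result is likewise a limit, > 39800 nM. Thus two of the three measured values sit at the limit of > 39800 nM in this assay, at which 2 of the 3 values shown sit, and compound 1 alone stands as a measured number in this assay.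

The unmeasured compound 4, `Cc1cc(COc2ccc(F)cc2)nc(-c2ccccn2)n1`, differs from compound 1 by a single exchange: fluoro in place of methoxy on an aromatic carbon. Within the data shown here, no pair of measured compounds differs in one place only, so no measured step gives the size of this kind of change directly. Among the measured compounds shown here, what the measured set shows is that compound 1 is the only compound with a number, while the two others reach only the limit of this assay.

The change from compound 1 to compound 4 is therefore expected to be small, within the usual scatter or somewhat toward weaker inhibition, a 1.5-fold higher number from compound 1 to compound 4 (0.18 log units; within the scatter). For compound 4 the estimate in this assay is 12000 nM, with a range from 4000 nM to 39800 nM.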

Compound 4, half-maximal inhibitory concentration: 631 nM
Compound 4: the middle estimate sits 19-fold (1.28 log units) above what was measured; measured number outside the range, below it.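

In this assay, within the data shown here, fluoro in place of methoxy on this aromatic carbon, para to a large group, gives a 13-fold lower number from compound 1 to compound 4 (1.10 log units; beyond the scatter), the first step in the set that can be read and one that lies beyond the scatter. The position is therefore not indifferent to what it carries, and here the stronger inhibition goes with the group of one heavy atom and no hydrogen-bond acceptor rather than the group of two heavy atoms and one acceptor, though this single pair cannot show which of these differences matters, or whether either does. Compound 2 and compound 3 remain at a limit of the assay, and no steps involving them can be read: the limit of > 39800 nM in this assay, at which 2 of the 4 values shown sit.

Going by these compounds, whether chloro, a nitrile or plain hydrogen on this same carbon would follow fluoro or methoxy remains open, so the step cannot yet be assigned to the arrival of fluoro rather than the departure of methoxy. Also open, on these data alone, is whether fluoro on another carbon of this ring, or an ethoxy or trifluoromethyl group at this place, would give a step of similar size.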